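This account rests on a few compounds, and the source may have more. Where it says the series, first, only, none or still open, it means among the compounds named here.

Working notes on the series, read in a functional assay on A549 cells (Homo sapiens) for cytotoxicity, read by MTT assay, with a stated time of 48 h; on this read-out higher numbers stand for weaker inhibition and lower numbers for stronger inhibition. Compound 2 `CCCNCCOc1c(O)cc(O)c2c(=O)cc(-c3ccccc3)oc12` has no number to stand on, as its entry for compound 2 is "not determined" (no result reported). The only other entry in the series is also not a number. Compound 1 `CCN(CC)CCCOc1c(O)cc(O)c2c(=O)cc(-c3ccccc3)oc12` gives > 100000 nM, which is a limit of the assay.

The next structure is compound 3 `O=c1cc(-c2ccccc2)oc2c(OCCCN3CCCC3)c(O)cc(O)c12`, not yet measured. The change is (pyrrolidin-1-yl)methyl in place of propylamino on a saturated chain carbon, two bonds along the chain from an oxygen on an aromatic ring. Cut one bond further out, the same difference reads 2-(propylamino)ethoxy to 3-(pyrrolidin-1-yl)propoxy, on the shared core.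

Going by the values given here, no measured step exists, so the effect of this change cannot be sized from data. With no result for compound 2, the size of the step in this assay has no starting point, and no shift beyond the scatter is assumed in either direction. The sole anchor for the expectation is compound 1 at > 100000 nM, again a limit, so weak inhibition is expected to carry over.

For compound 3 the expected value is 70000 nM, with an estimated range of 20000 nM to 150000 nM.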

Compound 3, half-maximal inhibitory concentration: > 100000 nM
Compound 3 was reported as a limit; the forecaster's own chance of this, stated with the estimate: 50%; middle value at least 1.4-fold (0.15 log units) from the limit.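

No step can be read among compound 1, compound 2 and compound 3, as compound 2 offers no number and the other two give only a shared limit: the limit of > 100000 nM in this assay, at which 2 of the 3 values shown sit.

The compounds shown leave open whether any member of the series has a measurable potency in this assay, and what size the change from 2-(propylamino)ethoxy to 3-(pyrrolidin-1-yl)propoxy has there.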